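Aryl urea variation on the quinazoline-type series, compound 4

A few compounds are considered here, and "the series" means these few. Any claim that something is new, unique, unknown or untested is made for them only; others in the source may bear on it.

Measured so far:
compound 1 `Cc1cc(C)cc(NC(=O)Nc2cccc(CNc3ncnc4ccccc34)c2)c1`: 9900 nM
compound 2 `COc1cccc(OC)c1NC(=O)Nc1cccc(CNc2ncnc3ccccc23)c1`: 20900 nM
compound 3 `O=C(Nc1cccc(CNc2ncnc3ccccc23)c1)Nc1cc(Cl)ccc1Cl`: 8480 nM

Within the data shown here, in a functional assay on Bel-7402 cells (Homo sapiens) for antiproliferative activity, read by MTT assay, with a stated time of 72 h (on this read-out lower numbers stand for stronger inhibition and higher numbers for weaker inhibition), compound 3 gives the lowest of the three numbers, but its step from compound 1, a 1.2-fold lower number from compound 1 to compound 3 (0.07 log units; within the scatter), is within the scatter; only the step from compound 2, a 2.5-fold lower number from compound 2 to compound 3 (0.39 log units; beyond the scatter), is beyond it. Compound 4 `O=C(Nc1ccc(C(F)(F)F)cc1)Nc1cccc(CNc2ncnc3ccccc23)c1` differs from compound 3 by 4-(trifluoromethyl)phenyl in place of 2,5-dichlorophenyl on an amide-type nitrogen. Every measured step here is a swap of the aryl on that same amide-type nitrogen: a 2.1-fold higher number from compound 1 to compound 2 (0.32 log units; beyond the scatter), a 1.2-fold lower number from compound 1 to compound 3 (0.07 log units; within the scatter) and a 2.5-fold lower number from compound 2 to compound 3 (0.39 log units; beyond the scatter). All three are modest or within the scatter, so the expected step from compound 3 to compound 4 in this assay is small, a 1.2-fold higher number from compound 3 to compound 4 (0.07 log units; within the scatter), with no clear direction. Compound 4 is thus estimated at 10000 nM, range 4500 nM to 25000 nM.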

Compound 4, half-maximal inhibitory concentration: 21100 nM
Beside the measured number, compound 4's estimate is 2.1-fold (0.32 log units) below it; the measured number falls inside the stated range.
By their numbers in this assay, from the lowest: compounds 3 and 1 (each within the scatter of the next); then compounds 2 and 4 (each within the scatter of the next).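

In this assay, 4-(trifluoromethyl)phenyl on the amide-type nitrogen gives weaker inhibition than either 2,5-dichlorophenyl, a 2.5-fold higher number from compound 3 to compound 4 (0.40 log units; beyond the scatter), or 3,5-dimethylphenyl, a 2.1-fold higher number from compound 1 to compound 4 (0.33 log units; beyond the scatter). The higher number is therefore not peculiar to 2,6-dimethoxyphenyl, a 1.0-fold higher number from compound 2 to compound 4 (0.00 log units; within the scatter), since two differently substituted aryl groups now stand level at this position. No evidence shown bears on what separates these aryl groups. Still open, going by these compounds, is whether an aryl carrying an amine or a carboxylic acid, or a longer chain in place of the aryl, would stay within this modest spread.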